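The source may hold more compounds than are shown below. What is called first, only, known or untested is meant among the compounds shown, and "the series" means these compounds.

Of the compounds shown here, three of one series have so far been measured in an ADME assay on MT4 cells (Homo sapiens) for cytotoxicity, read by MTT assay; a higher number here means that more compound is tolerated, a lower number that less compound is tolerated. Compound 1 `CCOC(=O)/C(O)=C/C(=O)c1cn(Cc2cc(F)c(F)c(F)c2)c2cccc(OC)c12` gives 33400 nM. Compound 2 `COc1cccc2c1c(C(=O)/C=C(\O)C(=O)O)cn2Cc1ccc(F)cc1` gives 41100 nM. Compound 3 `CCOC(=O)/C(O)=C/C(=O)c1cn(Cc2ccc(F)cc2F)c2cccc(OC)c12` gives 65500 nM. Among these three numbers compound 2 holds the second highest; its nearest neighbour is compound 1, whose value sits within the scatter of it, and its furthest is compound 3, whose value likewise remains within the scatter. Compound 1 and compound 2 differ in more than one place, so their two values can only be set side by side.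

Compound 4 `COc1cccc2c1c(C(=O)/C=C(\O)C(=O)O)cn2Cc1c(F)ccc(F)c1F` has not yet been measured. It differs from compound 2 in one place: 2,3,6-trifluorophenyl in place of 4-fluorophenyl on a saturated chain carbon bound to an aromatic nitrogen. For the measured compounds named here, the one measured step that swaps one fluorinated phenyl for another at the same place is a 2.0-fold higher number from compound 1 to compound 3 (0.29 log units; within the scatter), and it stayed within the scatter. Going by the values given here, no other measured step bears on this change. On that basis no step beyond the scatter is expected in this assay from compound 2 to compound 4, the expected step being a 1.1-fold higher number from compound 2 to compound 4 (0.04 log units; within the scatter). For compound 4 the estimated value is therefore 45000 nM, expected to fall between 20000 nM and 95000 nM.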

Compound 4, half-maximal cytotoxic concentration: 49400 nM
Estimate against measurement, compound 4: 1.1-fold (0.04 log units) below; the measured number falls inside the stated range.
By their numbers in this assay, from the lowest: compounds 1, 2, 4 and 3 (each within the scatter of the next).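

In this assay, the place on a saturated chain carbon bound to an aromatic nitrogen has now been varied on a second background: the earlier swap of one fluorinated phenyl for another was read on ethyl esters, whereas this one is read on the carboxylic acid. Putting 2,3,6-trifluorophenyl in place of 4-fluorophenyl gives a 1.2-fold higher number from compound 2 to compound 4 (0.08 log units; within the scatter), so with this second swap, too, the tolerated concentration does not move beyond the scatter, and the four fluorinated compounds shown cannot be told apart in this assay by their fluorine pattern. No measurement at hand offers an explanation for this flat result.

Going by these compounds, what remains open is whether this tolerance extends to groups of another kind at the same place, such as a phenyl carrying an amine or a methoxy group, an unsubstituted phenyl, or a longer chain leading to the ring. Also open is what the ethyl ester and the carboxylic acid do when compared directly, since no pair shown carries the same fluorinated phenyl on both.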